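Selenium for sulfur across two cytotoxicity scaffolds

This account rests on a few compounds, and the source may have more. Where it says the series, first, only, none or still open, it means among the compounds named here.

Three compounds are measured in a functional assay on K562 cells (Homo sapiens) for cytotoxicity, read by MTT assay, with a stated time of 72 h; on this read-out lower numbers stand for stronger inhibition of growth and higher numbers for weaker inhibition of growth. Compound 1 `CS/C(=N\C(=O)c1sccc1Cl)NC(=O)c1sccc1Cl` gives 37000 nM. Compound 2 `CS/C(=N\C(=O)c1cc(-c2ccccc2)nc2ccccc12)NC(=O)c1cc(-c2ccccc2)nc2ccccc12` gives 34400 nM, and compound 3 `C[Se]/C(=N\C(=O)c1cc(-c2ccccc2)nc2ccccc12)NC(=O)c1cc(-c2ccccc2)nc2ccccc12` gives 5800 nM. Compound 1 and compound 2 lie within the scatter of each other; the difference between their two cores is not broken down here. The change a group of 2 heavy atoms (1 carbon, 1 selenium; no ring) in place of a group of 2 heavy atoms (1 carbon, 1 sulfur; no ring), on a carbon with a double bond to nitrogen went with a 5.9-fold lower number from compound 2 to compound 3 (0.77 log units; beyond the scatter). Compound 4 `C[Se]/C(=N\C(=O)c1sccc1Cl)NC(=O)c1sccc1Cl` is not yet measured; it differs from compound 1 by a group of 2 heavy atoms (1 carbon, 1 selenium; no ring) in place of a group of 2 heavy atoms (1 carbon, 1 sulfur; no ring), on a carbon with a double bond to nitrogen, the same change, at a place described in the same words. The expected step in this assay is a 5.3-fold lower number from compound 1 to compound 4 (0.72 log units; beyond the scatter), resting on a 5.9-fold lower number from compound 2 to compound 3 (0.77 log units; beyond the scatter) and taken as carrying over to the core of compound 1. Compound 4 is therefore expected to give about 7000 nM, estimated to fall between 3000 nM and 18000 nM.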

Compound 4, concentration for 50% growth inhibition: 4810 nM
Compound 4: middle estimate off by 1.5-fold (0.16 log units), on the high side, within the range that was stated.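

In this assay, replacing methylsulfanyl with its selenium counterpart gave a 7.7-fold lower number from compound 1 to compound 4 (0.89 log units; beyond the scatter), and the change behaved alike on both cores: the same change on two cores in this assay, a 5.9-fold lower number (0.77 log units; beyond the scatter) from compound 2 to compound 3 and a 7.7-fold lower number (0.89 log units; beyond the scatter) from compound 1 to compound 4, 1.3-fold (0.11 log units) apart, within the scatter of two such steps. Within these two pairs, then, the step carried from one core to the other without a size difference that can be told apart from the scatter. Two pairs in one cell line do not show that the step will hold on further cores or in other cells, and they give no reason for it.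

From the compounds shown here alone, it remains open whether the step survives a longer chain on the selenium, such as ethyl or benzyl. Also open, going by these compounds, is how a methoxy group or an amine would compare on the same carbon.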